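A few compounds are considered here, and "the series" means these few. Any claim that something is new, unique, unknown or untested is made for them only; others in the source may bear on it.

Of the compounds shown here, three sharing one core have so far been measured in a functional assay on A-375 cells (Homo sapiens) for antiproliferative activity, read by MTT assay, with a stated time of 24 h, tested at 11.11 ug/mL; a higher number here means a stronger effect of the compound at the concentration tested, a lower number a weaker effect. Compound 1 `CCOc1ccc2nc(C(=O)Nc3c(F)cc(-c4cccc(F)c4)cc3F)c(C)c(O)c2c1` gives 15.3%, compound 2 `Cc1c(C(=O)Nc2c(F)cc(-c3cccc(F)c3)cc2F)nc2ccc(C(F)(F)F)cc2c1O` gives 46.3%, and compound 3 `COc1ccc2nc(C(=O)Nc3ccc(-c4ccccc4)cc3)c(C)c(O)c2c1` gives 36.2%. Compound 3 therefore stands second of the three numbers, below compound 2 and above compound 1, with both gaps beyond the scatter. Within the data shown here, the only step between compounds that differ in one place is a number 31 percentage points higher from compound 1 to compound 2 (beyond the scatter), a trifluoromethyl in place of ethoxy on an aromatic carbon. Compound 4 `Cc1c(C(=O)Nc2ccc(-c3ccccc3)cc2)nc2ccccc2c1O` differs from compound 3 by hydrogen in place of methoxy on an aromatic carbon. Among the measured compounds shown here, no measured step removes a methoxy for hydrogen, so the step from compound 1 to compound 2 bears on it only loosely, and no shift beyond the scatter is expected. For compound 4 the estimate is 32%, within 15% to 50%, an expected step of a number 4.2 percentage points lower from compound 3 to compound 4 (within the scatter).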

Compound 4, a percentage reported as inhibition, at one concentration (the size of the read-out at that concentration, not a potency): 26.5%
Compound 4: middle estimate off by 5.5 percentage points, on the high side; measured number inside the range.
By their numbers in this assay, from the lowest: compound 1; then compounds 4 and 3 (each within the scatter of the next); then compound 2.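

In this assay, hydrogen in place of methoxy on this aromatic carbon gives a number 9.7 percentage points lower from compound 3 to compound 4 (within the scatter). Among these compounds, this is the first measured step that simply removes a group from this position, and with this amide part the methoxy can go without a shift beyond the scatter. Nothing available points to a cause for this result.

Open, from the compounds shown here alone, is whether an amine or a carboxylic acid on this carbon would move the number. Also open, going by these compounds, is whether removing methoxy has the same outcome with the amide part of compound 1 and compound 2.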